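This account rests on a few compounds, and the source may have more. Where it says the series, first, only, none or still open, it means among the compounds named here.

In an ADME assay on MRC5 cells (Homo sapiens) for cytotoxicity (a higher number here means a weaker inhibitor, a lower number a stronger inhibitor), compound 1 `COc1ccc(Cn2cc(CNC(=O)c3ccc([N+](=O)[O-])o3)nn2)cc1O` gives 189000 nM. Compound 2 `O=C(NCc1cn(Cc2ccc(C(F)(F)F)cc2)nn1)c1ccc([N+](=O)[O-])o1` gives 321000 nM, and compound 3 `COc1ccc(Cn2cc(CNC(=O)c3ccc([N+](=O)[O-])o3)nn2)cc1` gives 146000 nM. Compound 1 therefore stands within the scatter of both other compounds. Compound 4 `COc1cc(Cn2cc(CNC(=O)c3ccc([N+](=O)[O-])o3)nn2)ccc1F` differs from compound 1 by this change: 4-fluoro-3-methoxyphenyl in place of 3-hydroxy-4-methoxyphenyl on a saturated chain carbon bound to an aromatic nitrogen. Going by the values given here, two measured steps bear on it. Hydrogen in place of hydroxy on an aromatic carbon brought a 1.3-fold lower number from compound 1 to compound 3 (0.11 log units; within the scatter), while methoxy in place of trifluoromethyl on an aromatic carbon brought a 2.2-fold lower number from compound 2 to compound 3 (0.34 log units; beyond the scatter). Among the compounds with values here, no measured compound carries the 4-fluoro-3-methoxyphenyl group, so this comparison is only indirect, and no step beyond the scatter is expected in this assay. The expected step is a 1.1-fold lower number from compound 1 to compound 4 (0.02 log units; within the scatter). For compound 4 the estimated value is 180000 nM, with an expected range from 95000 nM to 330000 nM.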

Compound 4, half-maximal inhibitory concentration: 155000 nM
The estimate for compound 4 lay 1.2-fold (0.06 log units) above the measured number; measured number inside the range.
By their numbers in this assay, from the lowest: compounds 3, 4, 1 and 2 (each within the scatter of the next, the first and the last beyond it).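

In this assay, the 4-fluoro-3-methoxyphenyl group in place of 3-hydroxy-4-methoxyphenyl brings a 1.2-fold lower number from compound 1 to compound 4 (0.09 log units; within the scatter), and the same group in place of 4-methoxyphenyl brings a 1.1-fold higher number from compound 3 to compound 4 (0.03 log units; within the scatter). On a saturated chain carbon bound to an aromatic nitrogen, then, this swap removes the hydrogen-bond donor of compound 1 and adds fluorine, yet neither step leaves the scatter. No supporting data are available to explain why these numbers stay so close. Still open, going by these compounds, is whether an amine or a carboxylic acid on this ring would bring a step beyond the scatter.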